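Piperazine amide series: a chloro replacement on an inactive parent

The source may report more compounds than this note shows. Statements on the series, on what has been measured and on what is new or still open speak of the compounds shown alone.

Measured in a functional assay on HL-60 cells (Homo sapiens) for inhibition, read by MTT assay, with a stated time of 72 h; on this read-out higher numbers stand for weaker inhibition and lower numbers for stronger inhibition:
- compound 1 `COc1ccc(-c2nc(C)oc2C(=O)N2CCN(c3cccc(Cl)c3)CC2)cc1`: "not active" (no number reported)
- compound 2 `C=C(C)c1cccc(N2CCN(C(=O)c3oc(C)nc3-c3ccccc3F)CC2)c1`: "not active" (no number reported)
- compound 3 `CCc1nc(-c2ccc(OC)cc2)c(C(=O)N2CCN(c3cccc(Cl)c3)CC2)o1`: > 1000 nM

Compound 2 stands without a number in this assay; its entry reads "not active" (no number reported). The other two entries give no number either. For compound 3 the value in this assay is a limit, > 1000 nM, and not a measured concentration. That is the only limit among the three values shown, namely (the limit of > 1000 nM in this assay, at which 1 of the 3 values shown sits). Compound 1 likewise carries no number. Compound 2 therefore sits among entries that show no measurable inhibition in this assay.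

Compound 4 `Cc1nc(-c2ccccc2F)c(C(=O)N2CCN(c3cccc(Cl)c3)CC2)o1` has not yet been measured in this assay. It differs from compound 2 by chloro in place of 1-methylethenyl on an aromatic carbon, the same difference read one bond further out being 3-(1-methylethenyl)phenyl to 3-chlorophenyl. Among the compounds with values here, no measured step between any two compounds exists here. Compound 4 shares its 3-chlorophenyl with compound 1 and compound 3, neither of which gives a number. The step from compound 2 to compound 4 is expected to be none beyond the scatter in this assay. Compound 4 is expected to give about 5000 nM, estimated between 1500 nM and 30000 nM, most likely reported only as a limit.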

Compound 4, half-maximal inhibitory concentration: 39.4 nM
Estimate against measurement, compound 4: 130-fold (2.10 log units) above; the measured number lies below the stated range.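

No step can be read from these results: compound 2 carries no number, so compound 4, at 39.4 nM, cannot be set against it. The compounds shown leave open how large the change from 1-methylethenyl to chloro is on this shared core.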